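The compounds below may be only part of what the source reports. "The series", "measured", "known", "first", "only" and "open" are said of these compounds alone.

Working notes on the series in a functional assay on HO8910 cells (Homo sapiens) for inhibition, read by MTT assay, with a stated time of 24 h, tested at 1 ug/mL; a lower number here means less inhibition of growth, a higher number more inhibition of growth at the concentration tested:

- compound 1 `O=C(CCCCC1CCSS1)Nc1ccc(Br)cn1`: 4.27%
- compound 2 `O=C(CCCCC(S)CCS)Nc1ccccn1`: "not active" (no number reported)
- compound 3 `O=C(CCCCC(S)CCS)Nc1ccc(Cl)cn1`: "not active" (no number reported)

Compound 3 has no single number in this assay. Its entry reads "not active" (no number reported), and the only other entry without a number is that of compound 2, which reads "not active" (no number reported). Among the compounds with values here, the sole numeric reading belongs to compound 1, at 4.27%, so the series offers one number and two qualitative entries.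

Compound 4 `O=C(CCCCC(S)CCS)Nc1ccc(Br)cn1` remains unmeasured. The structural change is bromo in place of chloro on an aromatic carbon, para to a large group. Within the data shown here, no measured pair differs in one place only, so this exchange has no direct precedent here. The expectation is for no step beyond the usual scatter in this assay, in either direction. This rests on compound 3 with "not active" (no number reported) and on the low reading of compound 1 at 4.27%. A report of no activity, without a number, would also fit these data. If a number is reported, the estimated value for compound 4 is 3%, with an expected range of 0% to 12%.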

Compound 4, percent growth inhibition at one concentration: 2.51%
For compound 4 the middle estimate is 0.5 percentage points above the measured one; the measured number falls inside the stated range.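

In this assay, within the data shown here, the group with no ring, in place of the group carrying the five-membered non-aromatic ring with 2 hetero atoms, on a saturated chain carbon, gives a number 1.8 percentage points lower from compound 1 to compound 4 (within the scatter) and so no change beyond the scatter, which is the first readable comparison at this place in the chain. The exchange of chloro for bromo on the aromatic carbon, para to a large group, cannot be read as a step, since compound 3 carries the entry "not active" (no number reported) and only compound 4 gives a number, 2.51% in this assay. No measurement at hand bears on why these entries fall as they do.

The compounds shown leave open whether a fluoro or a methoxy group on that same aromatic carbon would give a reading beyond the scatter from that of compound 4 in this assay. They also leave open whether a longer chain, or a carboxylic acid in place of the amide, would change the reading on the core of compound 4.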